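Chloro Added to the Benzamide of an Orexin Agonist Series

The source may hold more compounds than are shown below. What is called first, only, known or untested is meant among the compounds shown, and "the series" means these compounds.

Compound 1 `COc1ccc(-c2cccc(C(=O)N(C)C)c2)cc1S(=O)(=O)Nc1cccc(NCCNC(=O)c2ccccc2)c1` is the parent of this small set. In a functional assay on CHO-K1 cells for agonist activity at Orexin/Hypocretin receptor type 1 (Homo sapiens), read by calcium flux (a higher number here means a larger maximal response, a lower number a smaller maximal response), compound 1 gives "not determined" (no result reported), so no number stands for it there. Compound 2 `COc1ccc(C(=O)NCCNc2cccc(NS(=O)(=O)c3cc(-c4cccc(C(=O)N(C)C)c4)ccc3OC)c2)cc1` is in the same position: in this assay compound 2 gives "not determined" (no result reported). Among the compounds with values here, the one number available belongs to compound 3 `COc1ccc(-c2cccc(C(=O)N(C)C)c2)cc1S(=O)(=O)Nc1cccc(NCCNC(=O)c2ccccc2Cl)c1`, which carries a chloro on its benzamide ring and in this assay gives 50%.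

Compound 4 `COc1ccc(-c2cccc(C(=O)N(C)C)c2)cc1S(=O)(=O)Nc1cccc(NCCNC(=O)c2cccc(Cl)c2)c1` has yet to be tested. It differs from compound 1 in a single place: chloro in place of hydrogen on an aromatic carbon, the chloro sitting meta to a large group on the six-membered aromatic ring of carbon only, turning benzamido into ((3-chlorophenyl)carbonyl)amino. Because compound 1 gives "not determined" (no result reported) in this assay, the move from compound 1 to compound 4 cannot be expressed as a step of any size or direction; the scatter of the readout is the only yardstick for what a later comparison could reveal.

Within the data shown here, what can be said rests on compound 3, the sole chloro-bearing analogue with a result, 50% in this assay. On that basis, compound 4 is expected to give a maximal response of about 45% in this assay, most likely between 20% and 75%.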

Compound 4, largest response reached (Emax), in percent of the reference or control that the assay uses: 73%
Compound 4: the middle estimate sits 28 percentage points below what was measured; low and high end bracket the measured number.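

Within the data shown here, the first readable comparison in this set comes from two compounds that carry the same chloro on the same benzamide ring and differ only in where it sits: in this assay, 3-chlorophenyl in place of 2-chlorophenyl on the carbonyl carbon gives a number 23 percentage points higher from compound 3 to compound 4 (beyond the scatter). Among these compounds, this shows that the maximal response at this end of the molecule depends on the placement of the chloro and not merely on its presence, something that the single value for compound 3 could not show. No measurement among the data shown accounts for this difference, so the step stands as an observation without an explanation.

On these data alone, with no number for compound 1, the step from hydrogen to chloro cannot be read for either chloro compound, so it remains open whether either placement raises or lowers the response relative to the unsubstituted benzamide. Also open, as far as these compounds go, is whether the gain seen with compound 4 is specific to chloro or would hold with a fluoro, a methyl or a nitrile in its place on the same ring.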